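A Tail Swap on the Difluoro Analogue with the Lower Number

A few compounds are considered here, and "the series" means these few. Any claim that something is new, unique, unknown or untested is made for them only; others in the source may bear on it.

In a functional assay on the whole organism for inhibition, with Mus musculus as the target, with a stated time of 24 h, at a dose of 30 mg/kg by the oral route (a lower number here means less inhibition, a higher number more inhibition at the dose given (going by the name of the read-out)), compound 1 `CN1CCN(CCCN(c2nc3cc(F)c(F)cc3[nH]2)[C@@H]2CC[C@]3(c4cccc(C#N)c4)C[C@@H]3C2)CC1` gives 17%, the lowest of the two numbers at hand. Compound 2 `CN1CCN(CCCN(c2nc3cc(Cl)c(Cl)cc3[nH]2)[C@@H]2CC[C@]3(c4cccc(C#N)c4)C[C@@H]3C2)CC1` gives 97%; that measured step, a number 80 percentage points higher from compound 1 to compound 2 (beyond the scatter), lies in a different part of the molecule from the change now considered. Compound 3 `CS(=O)(=O)N1CCC(CN(c2nc3cc(F)c(F)cc3[nH]2)[C@@H]2CC[C@]3(c4cccc(C#N)c4)C[C@@H]3C2)CC1` differs from compound 1 by 1-(methylsulfonyl)piperidin-4-yl in place of 2-(4-methylpiperazin-1-yl)ethyl on a saturated chain carbon bound to a nitrogen on an aromatic ring. Among the measured compounds shown here, no measured step covers a change of this kind, so the data give no direction for it, and the expected step of a number 8 percentage points higher from compound 1 to compound 3 (within the scatter) is set near zero with a wide allowance. Compound 3 is therefore estimated at 25%, in the range 0% to 65%.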

Compound 3, a percentage reported as inhibition, in the whole organism at one dose (the size of the read-out at that dose, not a potency): 0%
Beside the measured number, compound 3's estimate is 25 percentage points above it; low and high end bracket the measured number.
By their numbers in this assay, from the lowest: compound 3; then compound 1; then compound 2.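

At this position, on a saturated chain carbon bound to a nitrogen on an aromatic ring, the choice of tail also moves the number in this assay: there is a number 17 percentage points lower from compound 1 to compound 3 (beyond the scatter) with 1-(methylsulfonyl)piperidin-4-yl in place of 2-(4-methylpiperazin-1-yl)ethyl. The earlier step covered only the halogens in a different part of the molecule. No evidence at hand bears on this result. As far as these compounds go, it remains open whether the step seen with 5,6-dichloro-1H-benzimidazol-2-yl carries over to this tail, and how a 1-acetylpiperidin-4-yl group or a primary amine at the chain end would read.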